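The source may hold more compounds than are shown below. What is called first, only, known or untested is meant among the compounds shown, and "the series" means these compounds.

Measured in a functional assay on HT-29 cells (Homo sapiens) for cytotoxicity, read by sulforhodamine B assay, with a stated time of 72 h; on this read-out higher numbers stand for weaker inhibition of growth and lower numbers for stronger inhibition of growth:
Compound 1 `CC(=O)/N=C1\NCCC(c2cn(C)c3ccccc23)N1`: 7400 nM
Compound 2 `CC(=O)/N=C1\NCCC(c2cn(C)c3ccc(Br)cc23)N1`: 310 nM

Of these two, compound 1 stands highest at 7400 nM. Compound 3 `CC(=O)/N=C1\NCCC(c2cn(C)c3cc(Br)ccc23)N1` differs from it by bromo in place of hydrogen on an aromatic carbon, with bromo in place of hydrogen on an aromatic carbon. For the measured compounds named here, only one measured step bears on this: a 24-fold lower number from compound 1 to compound 2 (1.38 log units; beyond the scatter), a large step from the same kind of swap, made at a different carbon. That single case suggests a lower number in this assay, though the different carbon leaves the size uncertain, so a somewhat smaller drop is expected. The expected change is a 7.4-fold lower number from compound 1 to compound 3 (0.87 log units; beyond the scatter). For compound 3 the estimated value is 1000 nM, with an expected range of 250 nM to 4500 nM.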

Compound 3, concentration for 50% growth inhibition: 4300 nM
For compound 3 the middle estimate is 4.3-fold (0.63 log units) below the measured one; low and high end bracket the measured number.
By their numbers in this assay, from the lowest: compound 2; then compounds 3 and 1 (each within the scatter of the next).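

Placing bromo on this carbon of the six-membered aromatic ring gives a 1.7-fold lower number from compound 1 to compound 3 (0.24 log units; within the scatter) in this assay, so here the swap has no clear effect on growth inhibition. The same swap at a different carbon gave a 24-fold lower number from compound 1 to compound 2 (1.38 log units; beyond the scatter), which shows that the benefit of bromo depends on which ring carbon carries it. Nothing available explains this difference between the two carbons.

On these data alone, it remains open whether chloro, methoxy or an amine at this carbon would match bromo here. The same question stands for those groups at the carbon bearing bromo in compound 2.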